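This account rests on a few compounds, and the source may have more. Where it says the series, first, only, none or still open, it means among the compounds named here.

Four compounds share one core and differ at two spots. Compound 2 `CN1C[C@@H](c2ccc(Cl)cc2)[C@@]2(Cc3ccccc3C2=O)[C@@]12C(=O)Nc1ccccc12` carries a chloro group on a phenyl ring and a hydrogen on a ring amide nitrogen. Compound 1 `Cc1ccc([C@@H]2CN(C)[C@]3(C(=O)Nc4ccccc43)[C@]23Cc2ccccc2C3=O)cc1` differs from it by methyl in place of chloro on an aromatic carbon. Compound 3 `CN1C(=O)[C@@]2(c3ccccc31)N(C)C[C@@H](c1ccc(Cl)cc1)[C@@]21Cc2ccccc2C1=O` keeps the chloro group but carries a methyl on that amide nitrogen. For the measured compounds named here, compound 4 `Cc1ccc([C@@H]2CN(C)[C@]3(C(=O)N(C)c4ccccc43)[C@]23Cc2ccccc2C3=O)cc1` has not yet been measured; it differs from compound 3 by methyl in place of chloro on an aromatic carbon, where the two place descriptions read word for word alike, so this is the same change as the one from compound 2 to compound 1.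

In a functional assay on the whole organism (strain Wister albino) for inhibition, with Rattus norvegicus as the target, read by paw edema, with stated times of 1 h and 2 h, at a dose of 50 mg/kg by the intraperitoneal route (on this read-out higher numbers stand for more inhibition at the one dose given (going by the name of the read-out) and lower numbers for less inhibition), compound 2 gives 28.4%, compound 1 gives 23.8% and compound 3 gives 36.3%. The swap of chloro for methyl gave a number 4.6 percentage points lower from compound 2 to compound 1 (within the scatter), and the methyl on the amide nitrogen gave a number 7.9 percentage points higher from compound 2 to compound 3 (within the scatter). Neither step rises above the usual scatter of this read-out; only the gap between compound 3 and compound 1 lies beyond it.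

The two cores on which the swap is made differ by methyl in place of hydrogen on an amide-type nitrogen in a ring. The change from compound 3 to compound 4 is expected to behave like the earlier one: because that earlier swap gave a number 4.6 percentage points lower from compound 2 to compound 1 (within the scatter), a step of similar size is expected, and compound 4 should come out at a number 4.3 percentage points lower from compound 3 to compound 4 (within the scatter). Compound 4 is therefore estimated at 32%, with a likely span from 22% to 42%.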

Compound 4, a percentage reported as inhibition, in the whole organism at one dose (the size of the read-out at that dose, not a potency): 8%
Beside the measured number, compound 4's estimate is 24 percentage points above it; the whole stated range lies above it.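

Carrying a change from one core to another fails in this series. In this assay, the swap from 4-chlorophenyl to 4-methylphenyl gives a number 28.3 percentage points lower from compound 3 to compound 4 (beyond the scatter) once the amide nitrogen bears a methyl, so the small step seen on the core with the amide hydrogen is no guide to the step on the methylated core: the same change on two cores in this assay, a number 4.6 percentage points lower (within the scatter) from compound 2 to compound 1 and a number 28.3 percentage points lower (beyond the scatter) from compound 3 to compound 4, 23.7 percentage points apart, beyond the scatter of two such steps

Read from the other side, the same four compounds show that the methyl on the amide nitrogen does not keep its effect either, since on the core with the 4-methylphenyl group it gives a number 15.8 percentage points lower from compound 1 to compound 4 (beyond the scatter): the same change on two cores in this assay, a number 7.9 percentage points higher (within the scatter) from compound 2 to compound 3 and a number 15.8 percentage points lower (beyond the scatter) from compound 1 to compound 4, 23.7 percentage points apart, beyond the scatter of two such steps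

The two spots therefore do not act independently here, so adding up separate steps fails for this set, but four compounds at a single dose show neither why this happens nor whether it holds beyond them.

Going by these compounds, it remains open whether a fluoro or methoxy group on the same aromatic carbon would behave more like the chloro group of compound 3 or the methyl group of compound 4. An ethyl group or a longer chain on the amide nitrogen leaves the same question open for the second spot.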